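The source may report more compounds than this note shows. Statements on the series, on what has been measured and on what is new or still open speak of the compounds shown alone.

Going by the values given here, in a functional assay on SK-OV-3 cells (Homo sapiens) for cytotoxicity, read by MTT assay, with a stated time of 48 h (on this read-out lower numbers stand for stronger inhibition and higher numbers for weaker inhibition), compound 1 `Cc1ccc2[nH]c(=O)c(-c3nc4cc(Cl)ccc4[nH]3)cc2c1` gives 33000 nM, the only number among the three compounds measured so far. Compound 2 `Cc1cc2nc(-c3cc4ccccc4[nH]c3=O)[nH]c2cc1C` reaches only the limit of > 100000 nM in this assay. Compound 3 `COc1ccc2[nH]c(=O)c(-c3nc4cc(C)c(C)cc4[nH]3)cc2c1` likewise reaches only the limit of > 100000 nM. The step that the two limits leave unreadable from compound 2 to compound 3 is therefore not readable, and the limit of > 100000 nM in this assay, at which 2 of the 3 values shown sit, marks where two of the three values sit. Compound 4 `Cc1ccc2[nH]c(=O)c(-c3nc4cc(Br)ccc4[nH]3)cc2c1` carries bromo in place of chloro on an aromatic carbon. Among the compounds with values here, none of the measured steps concerns a swap of one halogen for another, so no directly comparable step is in hand. The change is expected to move the value little, and the estimated step of a 1.1-fold lower number from compound 1 to compound 4 (0.04 log units; within the scatter) stays within the scatter. Compound 4 is accordingly estimated at 30000 nM, between 12000 nM and 80000 nM.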

Compound 4, half-maximal inhibitory concentration: > 100000 nM
Compound 4 gave a limit, no number; the forecaster's own chance of this, stated with the estimate: 15%; middle value at least 3.3-fold (0.52 log units) from the limit.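

In this assay, this aromatic carbon does not treat the two halogens alike: the swap of chloro for bromo gives the first readable step among these compounds, an at least 3.0-fold higher number from compound 1 to compound 4 (0.48 log units; beyond the scatter). Compound 4 gives only a limit, > 100000 nM, and not a number. Compound 1 thus remains the only compound here with a number: the limit of > 100000 nM in this assay, at which 3 of the 4 values shown sit.

On these data alone, what fluoro, an amine or a carboxylic acid on this carbon would do to the value of compound 1 stays open. Also open, as far as these compounds go, is how large the step really is, since it ends at a limit.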